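A few compounds are considered here, and "the series" means these few. Any claim that something is new, unique, unknown or untested is made for them only; others in the source may bear on it.

Among the measured compounds shown here, compound 3 `CC1(C)[C@H]2CC[C@]1(C)N(Cc1cn(-c3cccc(Br)c3)nn1)C(=O)C2` gives 90 nM in a functional assay on A549 cells (Homo sapiens) for inhibition, read by MTT assay, with a stated time of 24 h (on this read-out higher numbers stand for weaker inhibition and lower numbers for stronger inhibition), the second highest of the three numbers measured so far. Compound 1 `CC1(C)[C@H]2CC[C@]1(C)N(Cc1cn(-c3cccc(Cl)c3)nn1)C(=O)C2` gives 60 nM, and compound 2 `CC1(C)[C@H]2CC[C@]1(C)N(Cc1cn(-c3cccc(O)c3)nn1)C(=O)C2` gives 180 nM. Exchanging the chloro for hydroxy gave a 3.0-fold higher number from compound 1 to compound 2 (0.48 log units; beyond the scatter), whereas exchanging it for bromo gave a 1.5-fold higher number from compound 1 to compound 3 (0.18 log units; within the scatter); between the hydroxy and bromo compounds the difference was a 2.0-fold lower number from compound 2 to compound 3 (0.30 log units; within the scatter). Compound 4 `Cc1cccc(-n2cc(CN3C(=O)C[C@@H]4CC[C@@]3(C)C4(C)C)nn2)c1` differs from compound 3 by methyl in place of bromo on an aromatic carbon. For the measured compounds named here, no measured step replaces a halogen with methyl; the closest precedent, a 1.5-fold higher number from compound 1 to compound 3 (0.18 log units; within the scatter), stayed within the scatter, and only the hydroxy step moved beyond it. A change no larger than modest is therefore expected, a 1.1-fold higher number from compound 3 to compound 4 (0.05 log units; within the scatter). Compound 4 is estimated at 100 nM, within 45 nM to 220 nM.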

Compound 4, half-maximal inhibitory concentration: 50 nM
Compound 4: the middle estimate sits 2.0-fold (0.30 log units) above what was measured, and the stated range covers the measured number.
By their numbers in this assay, from the lowest: compounds 4, 1, 3 and 2 (each within the scatter of the next, the first and the last beyond it).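

Methyl behaves like the halogens at this position in this assay: a 1.8-fold lower number from compound 3 to compound 4 (0.26 log units; within the scatter) and a 1.2-fold lower number from compound 1 to compound 4 (0.08 log units; within the scatter) both stay within the scatter. Methyl, like chloro, is separated from hydroxy, with a 3.6-fold lower number from compound 2 to compound 4 (0.56 log units; beyond the scatter) beyond the scatter, while bromo is not, so the hydroxy compound is not set apart from all the others. Nothing available accounts for these differences. Going by these compounds, whether an amine, a carboxylic acid or a longer chain in this place would stay level with methyl and chloro remains open.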